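Piperazine-chain variant of compound 1: stability outlook

The compounds below may be only part of what the source reports. "The series", "measured", "known", "first", "only" and "open" are said of these compounds alone.

Measured compounds in an ADME assay on microsomes from liver (Rattus norvegicus) for metabolic stability, read by LC-MS, with a stated time of 10 min, tested at 0.5 uM; on this read-out higher numbers stand for a more stable compound and lower numbers for a less stable compound:
- compound 1 `c1ccc2c(c1)CN[C@@H](CN(CC[C@H]1CCCNC1)[C@H]1CCCc3cccnc31)C2`: 55%
- compound 2 `c1ccc2c(c1)CN[C@H](CN(CCCN1CCNCC1)[C@H]1CCCc3cccnc31)C2`: 88%
- compound 3 `c1cnc2c(c1)CCC[C@@H]2N(CCCN1CCNCC1)Cc1nc2ccccc2[nH]1`: 29%

Compound 1 sits second of the three. Compound 3 is the nearest, lower than compound 1 beyond the scatter; compound 2 is the furthest, higher than compound 1 beyond the scatter.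

The unmeasured compound 4 `c1ccc2c(c1)CN[C@@H](CN(CCCCN1CCNCC1)[C@H]1CCCc3cccnc31)C2` differs from compound 1 by 2-(piperazin-1-yl)ethyl in place of piperidin-3-yl on a saturated chain carbon, two bonds along the chain from an amine nitrogen.

Among the compounds with values here, only one single-point step has been measured, a number 59 percentage points lower from compound 2 to compound 3 (beyond the scatter), and it concerns a different position, so it does not bear directly on the change from compound 1 to compound 4. Within the data shown here, compounds 1 and 2 differ in more than one place; their values show the piperazine-bearing compound 2 with the higher number, but no single step can be drawn from that pair. The expectation for compound 4 therefore rests on the spread of the measured values rather than on a matched step. Compound 4 is expected to land between compounds 1 and 2, an estimated a number 15 percentage points higher from compound 1 to compound 4 (beyond the scatter). For compound 4 the estimate in this assay is 70%, with a range from 50% to 90%.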

Compound 4, percent of the compound remaining: 15%
Beside the measured number, compound 4's estimate is 55 percentage points above it; measured number outside the range, below it.
By their numbers in this assay, from the lowest: compound 4; then compound 3; then compound 1; then compound 2.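

At this position the side chain has a large influence on the read-out: in this assay, 2-(piperazin-1-yl)ethyl in place of piperidin-3-yl on a saturated chain carbon, two bonds along the chain from an amine nitrogen, gives a number 40 percentage points lower from compound 1 to compound 4 (beyond the scatter). This one step combines several differences, since the entering group has 8 heavy atoms against 6, a six-membered ring with 2 hetero atoms against 1, and no defined stereocentre, and the step does not separate them. Nothing measured here accounts for the size of this step.

Still open, going by these compounds, is whether the lower number follows the piperazine ring or the ethyl link. A 2-(piperidin-1-yl)ethyl or 2-(morpholin-4-yl)ethyl group at this place would help separate the two.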